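The source may report more compounds than this note shows. Statements on the series, on what has been measured and on what is new or still open speak of the compounds shown alone.

Measured compounds:
- compound 1 `Cc1ccc(S(=O)(=O)/C(=C/c2ccc(C)s2)C(=O)c2ccc(Br)cc2)cc1`: 25000 nM
- compound 2 `COc1ccc(/C=C(\C(=O)c2ccc(Br)cc2)S(=O)(=O)c2ccc(C)cc2)cc1`: 1000 nM

In a functional assay on DU-145 cells (Homo sapiens) for inhibition, read by trypan blue exclusion, with a stated time of 96 h (on this read-out lower numbers stand for stronger inhibition of growth and higher numbers for weaker inhibition of growth), compound 2 at 1000 nM has the lower of the two numbers, and the gap is beyond the scatter. The next compound to be tested, compound 3 `Cc1ccc(S(=O)(=O)/C(=C/c2ccc(N(C)C)cc2)C(=O)c2ccc(Br)cc2)cc1`, has dimethylamino in place of methoxy on an aromatic carbon, para to a large group: dimethylamino in place of methoxy on an aromatic carbon. For the measured compounds named here, no measured step changes this group directly. Going by the values given here, the only step that bears on it is a 25-fold lower number from compound 1 to compound 2 (1.40 log units; beyond the scatter), a large one, in which 4-methoxyphenyl replaced 5-methylthiophen-2-yl. That step shows that the number in this assay can move a long way with a change at this place, but it exchanged the whole aryl group. Compound 3 keeps the six-membered aromatic ring of compound 2 and changes only the group on it, so a far smaller change than a 25-fold lower number from compound 1 to compound 2 (1.40 log units; beyond the scatter) is expected, probably within the scatter and leaning towards a higher number. The expected step is a 1.5-fold higher number from compound 2 to compound 3 (0.18 log units; within the scatter). For compound 3 the estimated value is 1500 nM, with an expected range of 300 nM to 8000 nM.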

Compound 3, concentration for 50% growth inhibition: 50000 nM
For compound 3 the middle estimate is 33-fold (1.52 log units) below the measured one; measured number outside the range, above it.
By their numbers in this assay, from the lowest: compound 2; then compounds 1 and 3 (each within the scatter of the next).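

In this assay, the earlier step had exchanged the whole aryl group, so it could not show whether the group carried on the six-membered aromatic ring matters once that ring is in place. With a 50-fold higher number from compound 2 to compound 3 (1.70 log units; beyond the scatter), dimethylamino in place of methoxy on an aromatic carbon, para to a large group, proves to be a large change by itself, so keeping the ring does not keep the number; and with a 2.0-fold higher number from compound 1 to compound 3 (0.30 log units; within the scatter), the 4-(dimethylamino)phenyl and 5-methylthiophen-2-yl compounds stand within the scatter of each other, which leaves compound 2 as the only one of the three set apart from the others. Nothing in the available data accounts for this difference between methoxy and dimethylamino.

The compounds shown leave open whether methoxy is particular at this place, or whether a hydroxyl group, a primary amine, fluorine or a longer ether chain such as ethoxy would give a number like that of compound 2. Also open, on these data alone, is whether the large step between methoxy and dimethylamino would hold with chlorine in place of the bromine on the shared core.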